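A few compounds are considered here, and "the series" means these few. Any claim that something is new, unique, unknown or untested is made for them only; others in the source may bear on it.

The measured compounds:

Compound 1, `Nc1nc(N)c(CCCN(Cc2ccc(NC(CCC(=O)O)C(=O)O)cc2)c2cc(F)c(F)cc2[N+](=O)[O-])c(O)n1`: in a functional assay on CCRF-CEM cells (Homo sapiens) for cytotoxicity, in the presence of a further agent that is not named here (on this read-out lower numbers stand for stronger inhibition and higher numbers for weaker inhibition), compound 1 gives > 100000 nM, which is a limit of the assay and not a number.
Compound 2, `Nc1nc(N)c(CCCN(Cc2ccc(NC(CCC(=O)O)C(=O)O)cc2)c2ccc([N+](=O)[O-])c(F)c2F)c(O)n1`: in this assay compound 2 gives > 100000 nM, again a limit of the assay.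
Going by the values given here, compound 3, `CC(C)(C)OC(=O)CCC(Nc1ccc(CN(CCCc2c(N)nc(N)nc2O)c2ccc([N+](=O)[O-])c(F)c2F)cc1)C(=O)OC(C)(C)C`: in this assay compound 3 gives 20000 nM, the only number among the three.

Compound 1 and compound 2 share the same core and differ only in one place: 4,5-difluoro-2-nitrophenyl in place of 2,3-difluoro-4-nitrophenyl on an amine nitrogen. The step that the two limits leave unreadable from compound 2 to compound 1 cannot be read because of the limit of > 100000 nM in this assay, at which 2 of the 3 values shown sit. Compound 3 differs from compound 2 in a way that is not broken down here; all that can be said of the pair is that compound 2 sits at a limit while compound 3 shows a number.

Compound 4, `CC(C)(C)OC(=O)CCC(Nc1ccc(CN(CCCc2c(N)nc(N)nc2O)c2cc(F)c(F)cc2[N+](=O)[O-])cc1)C(=O)OC(C)(C)C`, has not been measured yet. It stands to compound 3 as compound 1 stands to compound 2, with the same change at the same place: 4,5-difluoro-2-nitrophenyl in place of 2,3-difluoro-4-nitrophenyl on an amine nitrogen. Among the compounds with values here, since the one earlier instance of this change was made between two limits, it gives no size to carry over. The expectation for compound 4 therefore rests on compound 3 alone, whose 20000 nM is the only anchor, and the step is expected to be small, a 1.3-fold higher number from compound 3 to compound 4 (0.10 log units; within the scatter). Compound 4 is estimated at 25000 nM in this assay, with a wide range from 5000 nM to 100000 nM, and a real chance that only a limit is reported.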

Compound 4, half-maximal inhibitory concentration: 3100 nM
Beside the measured number, compound 4's estimate is 8.1-fold (0.91 log units) above it; the whole stated range lies above it.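

On the core of compound 3, which carries two tert-butyl esters, putting 4,5-difluoro-2-nitrophenyl in place of 2,3-difluoro-4-nitrophenyl on the amine nitrogen has a measurable effect in this assay: the result is a 6.5-fold lower number from compound 3 to compound 4 (0.81 log units; beyond the scatter). The same change on the core of compound 1, which carries two free carboxylic acids, gives no size to compare, and the step there cannot be read, since compound 1 and compound 2 both stand at a limit and not at a number: the limit of > 100000 nM in this assay, at which 2 of the 4 values shown sit. The series therefore offers one readable instance of this change, which shows what it did on one core but does not show that the same size, or even the same direction, would carry over to another core.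

The compounds shown leave open how other groups on this amine nitrogen would behave, such as a plain phenyl or a 4-nitrophenyl with no fluorine, which would help separate the part played by the nitro group from that of the fluorines. They also leave open whether methyl esters in place of the tert-butyl esters would give numbers rather than limits, and with them a second readable instance of this change.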